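Moving the methyl on the aniline: solubility of compound 4

A few compounds are considered here, and "the series" means these few. Any claim that something is new, unique, unknown or untested is made for them only; others in the source may bear on it.

Measured compounds:
- compound 1 `COc1cc2nnc(C(N)=O)c(Nc3cc(C)ccc3F)c2cc1OC`: < 1000 nM (a limit of the assay)
- compound 2 `CCOc1cc2nnc(C(N)=O)c(Nc3cc(C)ccc3F)c2cc1N1CCN(C)CC1`: 120000 nM
- compound 3 `COc1cc2nnc(C(N)=O)c(Nc3ccc(C)cc3F)c2cc1N1CCN(C)CC1`: 87000 nM

Of the compounds shown here, three sharing one core have been tested in a physicochemical assay for solubility; on this read-out higher numbers stand for higher solubility and lower numbers for lower solubility. For compound 1 the assay reports only a limit, < 1000 nM, not a number. Compound 2 gives 120000 nM in this assay. Compound 3 gives 87000 nM, the lowest of the two numbers, yet its nearest neighbour is compound 2 and the gap between them lies within the scatter, so no order between the two can be claimed.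

Compound 4 `COc1cc2nnc(C(N)=O)c(Nc3cc(C)ccc3F)c2cc1N1CCN(C)CC1` has not yet been measured. It differs from compound 3 by 2-fluoro-5-methylphenyl in place of 2-fluoro-4-methylphenyl on a nitrogen on an aromatic ring; the two have the same atoms, joined differently. Going by the values given here, no measured pair shows this change on its own, so there is nothing to fix its direction or size. Because both numbers, compound 2 at 120000 nM and compound 3 at 87000 nM, sit close together, a rearrangement of the same atoms is expected to give a step of a 1.1-fold higher number from compound 3 to compound 4 (0.04 log units; within the scatter), none beyond the scatter. Compound 4 is therefore estimated at 95000 nM, with a range from 35000 nM to 250000 nM.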

Compound 4, solubility: 22000 nM
Compound 4: the middle estimate sits 4.3-fold (0.64 log units) above what was measured, and the stated range ends above it.
By their numbers in this assay, from the lowest: compound 4; then compounds 3 and 2 (each within the scatter of the next). At a limit, below all of these: compound 1.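

In this assay, 2-fluoro-5-methylphenyl in place of 2-fluoro-4-methylphenyl on the aniline nitrogen gives a 4.0-fold lower number from compound 3 to compound 4 (0.60 log units; beyond the scatter), so moving a single methyl, with the same atoms joined differently, is enough to shift this read-out beyond the scatter. A second small edit counts as well: hydrogen in place of methyl on the saturated chain carbon bound to the oxygen gives a 5.5-fold lower number from compound 2 to compound 4 (0.74 log units; beyond the scatter). The largest difference comes with 4-methylpiperazin-1-yl in place of methoxy on the aromatic carbon, an at least 22-fold higher number from compound 1 to compound 4 (1.34 log units; beyond the scatter), though compound 1 is reported only as a limit, so this step has no exact size: the limit of < 1000 nM in this assay, at which 1 of the 4 values shown sits.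

From the compounds shown here alone, whether the methyl's move has a similar effect alongside other groups on the shared core remains open. Also open, going by these compounds, is how a chlorine in place of that methyl, or an open-chain amine in place of 4-methylpiperazin-1-yl, would read.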